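Nitro in place of methyl on the fused ring

A few compounds are considered here, and "the series" means these few. Any claim that something is new, unique, unknown or untested is made for them only; others in the source may bear on it.

Within the data shown here, compound 2 `CCOC(=O)c1c(-c2ccccc2)nn(-c2ccccc2)c1Cn1cnc2cc(C)ccc21` gives 45 ug/mL in an assay for inhibition of Alpha amylase (Homo sapiens), with a stated time of 30 min (on this read-out lower numbers stand for stronger inhibition and higher numbers for weaker inhibition), and stands alongside compound 1 `CCOC(=O)c1c(-c2ccccc2)nn(-c2ccccc2)c1Cn1cnc2ccccc21`, the only other measured compound, which gives 35 ug/mL; the step of a 1.3-fold higher number from compound 1 to compound 2 (0.11 log units; within the scatter) is within the scatter. Compound 3 `CCOC(=O)c1c(-c2ccccc2)nn(-c2ccccc2)c1Cn1cnc2cc([N+](=O)[O-])ccc21` differs from compound 2 by nitro in place of methyl on an aromatic carbon. Among the measured compounds shown here, only one measured step bears on this position, the methyl-for-hydrogen change from compound 1 to compound 2, and it was within the scatter; no nitro group has been measured. For compound 3 the expected step is a 1.1-fold lower number from compound 2 to compound 3 (0.05 log units; within the scatter), giving an estimate of 40 ug/mL with a range of 18 ug/mL to 90 ug/mL.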

Compound 3, half-maximal inhibitory concentration: 30 ug/mL
Beside the measured number, compound 3's estimate is 1.3-fold (0.12 log units) above it; low and high end bracket the measured number.
By their numbers in this assay, from the lowest: compounds 3, 1 and 2 (each within the scatter of the next).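

In this assay the nitro group on this aromatic carbon gives a 1.5-fold lower number from compound 2 to compound 3 (0.18 log units; within the scatter) and a 1.2-fold lower number from compound 1 to compound 3 (0.07 log units; within the scatter), so the second, larger replacement also leaves the read-out within the scatter. Hydrogen, methyl and nitro therefore cannot be ordered at this position. Nothing available accounts for this insensitivity. Still open, as far as these compounds go, is whether an amine or a carboxylic acid here would produce a step beyond the scatter. Also open, from the compounds shown here alone, is whether another part of the shared core, such as the ester if replaced by an amide, responds more strongly.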